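From fluoro to chloro on compound 2

A few compounds are considered here, and "the series" means these few. Any claim that something is new, unique, unknown or untested is made for them only; others in the source may bear on it.

Among the compounds with values here, in a functional assay on A2780 cells (Homo sapiens) for inhibition, with a stated time of 72 h (on this read-out higher numbers stand for weaker inhibition and lower numbers for stronger inhibition), compound 2 `CC(=O)O[C@@]1([C@@H]2/C(C)=C(/O)C(=O)C3=C(C)[C@@H](OC(=O)[C@H](O)[C@H](CC(C)C)NC(=O)OC(C)(C)C)C[C@@](O)([C@H]2OC(=O)c2cccc(F)c2)C3(C)C)CO[C@@H]1CCO` gives 11.8 nM, the highest of the three numbers so far and thus the weakest inhibition among them. Compound 3 `CC(=O)O[C@@]1([C@@H]2/C(C)=C(/O)C(=O)C3=C(C)[C@@H](OC(=O)[C@H](O)[C@H](C=C(C)C)NC(=O)OC(C)(C)C)C[C@@](O)([C@H]2OC(=O)c2cccc(F)c2)C3(C)C)CO[C@@H]1CCO` gives 4.9 nM, and compound 1 `CC(=O)O[C@@]1([C@@H]2/C(C)=C(/O)C(=O)C3=C(C)[C@@H](OC(=O)[C@H](O)[C@H](C=C(C)C)NC(=O)OC(C)(C)C)C[C@@](O)([C@H]2OC(=O)c2cccc(Cl)c2)C3(C)C)CO[C@@H]1CCO` gives 4 nM.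

Compound 4 `CC(=O)O[C@@]1([C@@H]2/C(C)=C(/O)C(=O)C3=C(C)[C@@H](OC(=O)[C@H](O)[C@H](CC(C)C)NC(=O)OC(C)(C)C)C[C@@](O)([C@H]2OC(=O)c2cccc(Cl)c2)C3(C)C)CO[C@@H]1CCO` differs from compound 2 in a single atom: chloro in place of fluoro on an aromatic carbon. In words, this is chloro in place of fluoro on an aromatic carbon. Within the data shown here, the one direct precedent runs the opposite way, in the pair carrying the 2-methylprop-1-en-1-yl group: a 1.2-fold higher number from compound 1 to compound 3 (0.09 log units; within the scatter). That step is small, though it is a single pair and may not carry over fully to the isobutyl compounds. The other measured step, a 2.4-fold lower number from compound 2 to compound 3 (0.38 log units; beyond the scatter), swaps isobutyl for 2-methylprop-1-en-1-yl, a change compound 4 does not make, so compound 4 should stay close to compound 2.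

In this assay no step beyond the scatter is therefore expected. The estimated step is a 1.2-fold lower number from compound 2 to compound 4 (0.07 log units; within the scatter). Compound 4 is expected to give about 10 nM, with an estimated range of 5.5 nM to 18 nM.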

Compound 4, half-maximal inhibitory concentration: 4.1 nM
The estimate for compound 4 lay 2.4-fold (0.39 log units) above the measured number, outside the stated range (below it).
By their numbers in this assay, from the lowest: compounds 1, 4 and 3 (each within the scatter of the next); then compound 2.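

Chloro in place of fluoro on this aromatic carbon is not always a silent change: in this assay the isobutyl compounds give a 2.9-fold lower number from compound 2 to compound 4 (0.46 log units; beyond the scatter), a modest step that the earlier pair did not show, yet the two steps cannot be firmly separated: the same change on two cores in this assay, a 1.2-fold higher number (0.09 log units; within the scatter) from compound 1 to compound 3 and a 2.9-fold higher number (0.46 log units; beyond the scatter) from compound 4 to compound 2, 2.3-fold (0.37 log units) apart, within the scatter of two such steps

The side chain now also looks less decisive, since with chloro on the aromatic ring the chain exchange gives a 1.0-fold higher number from compound 1 to compound 4 (0.01 log units; within the scatter), so the step seen with fluoro does not appear here, though this contrast is not firm either: the same change on two cores in this assay, a 2.4-fold lower number (0.38 log units; beyond the scatter) from compound 2 to compound 3 and a 1.0-fold lower number (0.01 log units; within the scatter) from compound 4 to compound 1, 2.3-fold (0.37 log units) apart, within the scatter of two such steps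

As far as these compounds go, whether the halogen and the chain truly depend on each other remains open, and repeat measurements of these four compounds would help settle it. Also open, from the compounds shown here alone, is how a methoxy group or a nitrile on this aromatic carbon would compare with fluoro and chloro.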